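A Second 2H-tetrazol-5-yl Group on Compound 2

This account rests on a few compounds, and the source may have more. Where it says the series, first, only, none or still open, it means among the compounds named here.

Compound 1 `O=C(Nc1cccc(-c2nn[nH]n2)c1)c1cccc(-c2nn[nH]n2)c1`: 15.8 mg/kg
Compound 2 `O=C(Nc1ccccc1)c1cccc(-c2nn[nH]n2)c1`: 38.1 mg/kg

Both values come from a functional assay on the whole organism (stomach) with Rattus norvegicus as the target; on this read-out lower numbers stand for an effect already at smaller amounts and higher numbers for an effect only at larger amounts of compound. Compound 2 has the higher number of the two, so it needs the larger dose for the same effect. Compound 3 `O=C(Nc1ccc(-c2nn[nH]n2)cc1)c1cccc(-c2nn[nH]n2)c1` is compound 2 with 2H-tetrazol-5-yl in place of hydrogen on an aromatic carbon, para to a large group: 2H-tetrazol-5-yl in place of hydrogen on an aromatic carbon.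

For the measured compounds named here, one measured step bears on this change. It is a 2.4-fold higher number from compound 1 to compound 2 (0.38 log units; beyond the scatter), a modest step beyond the scatter, in which hydrogen replaces 2H-tetrazol-5-yl. Going by the values given here, compound 3 makes the reverse kind of change, but its new group sits at a different place from the one in compound 1. Among the compounds with values here, no measured pair shows how much that place matters, so the earlier step is only a rough guide. A modest move to a lower number is therefore expected, though a result close to compound 2 remains possible. The expected change is a 1.9-fold lower number from compound 2 to compound 3 (0.28 log units; within the scatter). For compound 3 the estimated value is 20 mg/kg, with an expected range from 8 mg/kg to 50 mg/kg.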

Compound 3, dose for 50% inhibition: 0.6 mg/kg
Estimate against measurement, compound 3: 33-fold (1.52 log units) above, and the stated range ends above it.
By their numbers in this assay, from the lowest: compound 3; then compound 1; then compound 2.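

In this assay, putting 2H-tetrazol-5-yl in place of hydrogen on an aromatic carbon, para to a large group, gives a far bigger change than the earlier step hinted at (a 64-fold lower number from compound 2 to compound 3 (1.80 log units; beyond the scatter)). Compound 1 carries the same added group at a different place and gives (15.8 mg/kg), while compound 3 gives the lower number (0.6 mg/kg), so having a second 2H-tetrazol-5-yl group does not by itself set the dose needed; where it sits also matters in this series. Nothing available here explains why this position responds so strongly.

The three compounds cannot tell whether the gain belongs to 2H-tetrazol-5-yl itself or would also appear with another group at this place, such as a carboxylic acid or an amine. From the compounds shown here alone, the 2H-tetrazol-5-yl group that all three compounds share is never changed among them, so its own part in the effect, and whether compound 3 would keep its low number without it, remains unknown.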